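Quinoline ureas: cytotoxicity on the aryl ring

This account rests on a few compounds, and the source may have more. Where it says the series, first, only, none or still open, it means among the compounds named here.

Measured so far:
compound 1 `Cc1cc(NC(=O)Nc2ccc(C)c(Cl)c2)c2ccccc2n1` — > 25000 nM
compound 2 `Cc1cc(NC(=O)Nc2ccc(Cl)cc2)c2ccccc2n1` — > 25000 nM

In an ADME assay on HEK293 cells (Homo sapiens) for cytotoxicity, with a stated time of 72 h (on this read-out lower numbers stand for an effect already at smaller amounts and higher numbers for an effect only at larger amounts of compound), compound 1 gives > 25000 nM, which is a limit of the assay and not a number. In this assay compound 2 gives > 25000 nM, again a limit rather than a number. Within the data shown here, compound 2 therefore stands with the other measured compound at the limit of > 25000 nM in this assay, at which 2 of the 2 values shown sit; no numbers below that limit have been obtained, and no step between measured compounds can be sized.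

Compound 3 `Cc1cc(NC(=O)Nc2ccc(Cl)c(Cl)c2)c2ccccc2n1` is not yet measured. It differs from compound 2 by chloro in place of hydrogen on an aromatic carbon. With both measured compounds sitting at the limit, no step beyond the scatter is expected from compound 2 to compound 3 in this assay; the likeliest outcome for compound 3 is once more a limit. Compound 3 is estimated at 30000 nM, within 12000 nM to 100000 nM, which means an expected step that the limit leaves unreadable from compound 2 to compound 3.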

Compound 3, half-maximal effective concentration: > 25000 nM
Compound 3 ended at the assay's limit; the forecaster's own chance of this, stated with the estimate: 80%; the middle value does not contradict the limit.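

In this assay no step among compound 1, compound 2 and compound 3 can be read, and compound 3 adds only another limit: the limit of > 25000 nM in this assay, at which 3 of the 3 values shown sit.

The compounds shown leave open whether any change on the aryl ring gives a measurable value, and how large a step chloro would then produce.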